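This account rests on a few compounds, and the source may have more. Where it says the series, first, only, none or still open, it means among the compounds named here.

Measured in an assay on Sf9 cells for inhibition of protein deacetylase HDAC6 (Homo sapiens), read by fluorescence, with a stated time of 40 min, tested at 100 nM; on this read-out lower numbers stand for less inhibition and higher numbers for more inhibition at the one concentration tested (going by the name of the read-out):
Compound 1 `Cc1ccc(-c2nc(CNc3ccc(C(=O)NO)cc3)n(-c3ccccc3)n2)cc1` gives 62.2%.
Compound 2 `O=C(NO)c1ccc(NCc2nc(-c3cccc4cnccc34)nn2-c2ccccc2)cc1` gives 40.2%.
Compound 3 `O=C(NO)c1ccc(NCc2nc(-c3ccc(Br)cc3)nn2-c2ccccc2)cc1` gives 54.7%.

Compound 3 stands second highest of the three numbers. Its nearest neighbour is compound 1, which lies higher only within the scatter, while compound 2 lies lower beyond it: a number 14.5 percentage points higher from compound 2 to compound 3 (beyond the scatter). Compound 4 `O=C(NO)c1ccc(NCc2nc(-c3ccc(F)cc3)nn2-c2ccccc2)cc1` differs from compound 3 by fluoro in place of bromo on an aromatic carbon. Going by the values given here, no measured step touches fluoro. Among the compounds with values here, the step that bears on it most is the exchange at the same place, a number 7.5 percentage points lower from compound 1 to compound 3 (within the scatter), which stayed within the scatter; the only steps beyond the scatter, a number 22 percentage points lower from compound 1 to compound 2 (beyond the scatter) and the one already named, both involve compound 2. Compound 4 is therefore expected to move from compound 3 by no more than the scatter, a number 2.7 percentage points lower from compound 3 to compound 4 (within the scatter), in no set direction. The estimate for compound 4 in this assay is 52%, expected to lie between 38% and 66%.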

Compound 4, a percentage reported as inhibition, at one concentration (the size of the read-out at that concentration, not a potency): 70.9%
Compound 4: middle estimate off by 18.9 percentage points, on the low side, outside the stated range (above it).
By their numbers in this assay, from the lowest: compound 2; then compounds 3, 1 and 4 (each within the scatter of the next, the first and the last beyond it).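

In this assay, going by these compounds alone, the group on this aromatic carbon, para to a large group, proves able to shift the number without any change of ring: fluoro in place of bromo gives a number 16.2 percentage points higher from compound 3 to compound 4 (beyond the scatter), the first step beyond the scatter that does not involve compound 2. The widest step is now a number 30.7 percentage points higher from compound 2 to compound 4 (beyond the scatter), whereas fluoro and methyl cannot be told apart, with a number 8.7 percentage points higher from compound 1 to compound 4 (within the scatter). Nothing available explains why fluoro and bromo differ here. As far as these compounds go, what a chloro or a methoxy group would give at this place stays open, as does whether the step from bromo to fluoro would hold with other groups on the shared core.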